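The source may report more compounds than this note shows. Statements on the series, on what has been measured and on what is new or still open speak of the compounds shown alone.

Compound 1 `COc1ccc(C(=O)NOCc2ccccc2)cc1S(=O)(=O)Nc1ccc2c(c1)cc(C)c(=O)n2C`: in a functional assay on HL-60 cells (Homo sapiens) for antiproliferative activity, tested at 20 uM (on this read-out lower numbers stand for a weaker effect and higher numbers for a stronger effect at the one concentration tested), compound 1 gives 13%.
Compound 2 `COc1ccc(C(=O)NO)cc1S(=O)(=O)Nc1ccc2c(c1)cc(C)c(=O)n2C`: in this assay compound 2 gives 10%.

Going by the values given here, compound 2 stands at the lower of the two numbers measured, with compound 1 as its only neighbour, and the step of a number 3 percentage points lower from compound 1 to compound 2 (within the scatter) shows that the two do not separate beyond the scatter. The shared core is unchanged in both, and the difference between them sits on an oxygen of the amide side chain.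

Compound 3 `COC(=O)c1ccc(OC)c(S(=O)(=O)Nc2ccc3c(c2)cc(C)c(=O)n3C)c1` has not yet been measured in this assay. It differs from compound 2 as methoxy in place of hydroxyamino on a carbonyl carbon. Among the compounds with values here, no measured step touches this carbonyl carbon; the one step known, a number 3 percentage points lower from compound 1 to compound 2 (within the scatter), concerns a different place and was itself within the scatter. There is therefore no basis for expecting a change beyond the scatter in this assay in either direction. Compound 3 is expected to give 12%, in the range 0% to 30%. The estimated step of a number 2 percentage points higher from compound 2 to compound 3 (within the scatter) is expected to lie inside the scatter.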

Compound 3, a percentage reported as inhibition, at one concentration (the size of the read-out at that concentration, not a potency): 44%
Estimate against measurement, compound 3: 32 percentage points below; measured number outside the range, above it.
By their numbers in this assay, from the lowest: compounds 2 and 1 (each within the scatter of the next); then compound 3.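

The carbonyl carbon proved to be a place where the read-out responds in this assay: methoxy in place of hydroxyamino gives a number 34 percentage points higher from compound 2 to compound 3 (beyond the scatter), and methoxy in place of (benzyloxy)amino gives a number 31 percentage points higher from compound 1 to compound 3 (beyond the scatter). Both steps lie beyond the scatter and point the same way, so replacing either nitrogen-bearing group with methoxy raises the number, whereas the earlier change further out, on the oxygen of the side chain, did not separate compound 1 from compound 2. The information at hand offers no account of why this exchange at the carbonyl carbon raises the number.

The compounds shown leave open whether the rise belongs to methoxy itself or simply to the loss of the nitrogen-bearing groups, a question that a carboxylic acid, a primary amide or an ethoxy group on the same carbonyl carbon could help settle. They also leave open how compound 3 would behave at other concentrations, since a single-concentration read-out gives the size of an effect and not a potency.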